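Hydroxymethyl in Place of Methoxycarbonyl on a Shared Core

The compounds below may be only part of what the source reports. "The series", "measured", "known", "first", "only" and "open" are said of these compounds alone.

Three compounds on a shared core have been measured in a functional assay on MIA PaCa-2 cells (Homo sapiens) for cytotoxicity, read by MTT assay, with a stated time of 72 h; on this read-out lower numbers stand for stronger inhibition and higher numbers for weaker inhibition:
compound 1 `Cc1ccc(-c2ccc(NC3=CC(=O)c4ncncc4C3=O)cc2F)cc1` gives 4600 nM;
compound 2 `COc1cc(NC2=CC(=O)c3ncncc3C2=O)cc(OC)c1OC` gives 1500 nM;
compound 3 `COC(=O)c1ccc(NC2=CC(=O)c3ncncc3C2=O)cc1` gives 2200 nM.

Among these three numbers compound 3 holds the second highest. Its nearest neighbour is compound 2, whose number is lower, but the gap between compound 2 and compound 3 lies within the usual scatter of this assay, so no order can be read between them. Compound 1 stands furthest from compound 3, with a higher number, and that gap lies beyond the scatter.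

Compound 4 `O=C1C(Nc2ccc(CO)cc2)=CC(=O)c2ncncc21` has not been measured. It differs from compound 3 in one place: hydroxymethyl in place of methoxycarbonyl on an aromatic carbon.

No pair of measured compounds separated by a single change is available here, so the size of this step cannot be read from the numbers shown. In this assay the account expects compound 4 to sit close to compound 3, with no step beyond the scatter in either direction. The estimate for compound 4 is therefore 2500 nM, within a range from 900 nM to 7000 nM, which amounts to an expected step of a 1.1-fold higher number from compound 3 to compound 4 (0.06 log units; within the scatter).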

Compound 4, half-maximal inhibitory concentration: 3500 nM
Compound 4: middle estimate off by 1.4-fold (0.15 log units), on the low side, and the stated range covers the measured number.
By their numbers in this assay, from the lowest: compounds 2, 3, 4 and 1 (each within the scatter of the next, the first and the last beyond it).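

In this assay, among the compounds shown here, this is the first step on the shared core that can be read at a single place, and a 1.6-fold higher number from compound 3 to compound 4 (0.20 log units; within the scatter) stays within the scatter. For the compounds shown here, the aromatic carbon para to a large group therefore accepts an exchange of methoxycarbonyl, with 4 heavy atoms and 0 hydrogen-bond donors, for hydroxymethyl, with 2 heavy atoms and 1 hydrogen-bond donor, without a readable shift in the number, something the earlier compounds, which differ in more than one place, could not show. No measurement is available here that would explain this result.

A single step at one place cannot show whether other groups on the same aromatic carbon, such as a carboxylic acid, an aminomethyl group or a longer chain like hydroxyethyl, would also stay within the scatter of compound 3 or would move the number beyond it. It also leaves open whether hydroxymethyl and methoxycarbonyl would remain this close on a ring that carries further substituents, or on other cell lines.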